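The source may hold more compounds than are shown below. What is called first, only, known or untested is meant among the compounds shown, and "the series" means these compounds.

Compound 3 `COc1cccc(-c2nc3c(-c4cccc(Cl)c4)n[nH]c3c(=O)n2NC(=O)c2ccccc2)c1` stands highest of the three compounds measured in a functional assay on DU-145 cells (Homo sapiens) for cytotoxicity, read by sulforhodamine B assay, with a stated time of 2 days, tested at 100 uM (on this read-out lower numbers stand for less inhibition and higher numbers for more inhibition at the one concentration tested (going by the name of the read-out)), where compound 3 gives 93.5%. Compound 1 `COc1cccc(-c2nc3c(-c4ccc(Cl)cc4)n[nH]c3c(=O)n2NC(=O)c2ccncc2)c1` comes nearest, as in this assay compound 1 gives 54.4%, while compound 2 `CCCc1n[nH]c2c(=O)n(NC(=O)c3ccccc3)c(-c3cccc(OC)c3)nc12` lies furthest, giving 23.6% in this assay. For the measured compounds named here, the only single step measured is a number 69.9 percentage points higher from compound 2 to compound 3 (beyond the scatter), a large one. Compound 4 `COc1cccc(-c2nc3c(-c4ccc(Cl)cc4)n[nH]c3c(=O)n2NC(=O)c2ccccc2)c1` differs from compound 3 in one place: 4-chlorophenyl in place of 3-chlorophenyl on an aromatic carbon. Going by the values given here, no measured step isolates this swap; compound 1 also carries the 4-chlorophenyl but differs from compound 3 in a second place too, so its lower value only hints. The change a number 18.5 percentage points lower from compound 3 to compound 4 (beyond the scatter) is therefore expected to be a moderate fall, and compound 4 is estimated at 75%, between 50% and 95%.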

Compound 4, a percentage reported as inhibition, at one concentration (the size of the read-out at that concentration, not a potency): 94.1%
Compound 4: the middle estimate sits 19.1 percentage points below what was measured, and the stated range covers the measured number.
By their numbers in this assay, from the lowest: compound 2; then compound 1; then compounds 3 and 4 (each within the scatter of the next).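

In this assay, 4-chlorophenyl in place of 3-chlorophenyl changes little (a number 0.6 percentage points higher from compound 3 to compound 4 (within the scatter)), so at this position the two chlorophenyl groups cannot be told apart. The 4-chlorophenyl group also stands far from propyl (a number 70.5 percentage points higher from compound 2 to compound 4 (beyond the scatter)), as 3-chlorophenyl did. Chlorine placement therefore does not account for the low value of compound 1, and the step from it, phenyl in place of pyridin-4-yl on the carbonyl carbon (a number 39.7 percentage points higher from compound 1 to compound 4 (beyond the scatter)), points to that other ring instead.

No measurement offers a reason for these differences. On these data alone, whether plain phenyl, or a ring carrying an amine, would serve equally well at this position stays open.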